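A few compounds are considered here, and "the series" means these few. Any claim that something is new, unique, unknown or untested is made for them only; others in the source may bear on it.

Working notes on the series. The compounds share one core and differ at a single aromatic carbon. Compound 1 `CCOC(=O)CCCCCOc1cccc(CN(C(=O)c2ccc(-c3cccnc3)cc2)C(C)C)c1` carries pyridin-3-yl there, compound 2 `CCOC(=O)CCCCCOc1cccc(CN(C(=O)c2ccc(-c3ccoc3)cc2)C(C)C)c1` carries furan-3-yl, and compound 3 `CCOC(=O)CCCCCOc1cccc(CN(C(=O)c2ccc(-c3cccc(OCc4ccccc4)c3)cc2)C(C)C)c1` carries benzyloxy. In an ADME assay on HEK293 cells (Homo sapiens) for cytotoxicity, read by CellTiter-Glo and resazurin assay, with a stated time of 72 h (on this read-out higher numbers stand for an effect only at larger amounts of compound and lower numbers for an effect already at smaller amounts), compound 1 reaches only the limit > 26000 nM and no number. In this assay compound 2 likewise reaches only the limit > 26000 nM. In this assay compound 3 also gives only the limit > 26000 nM, so for compound 3 a limit is all that is known. Within the data shown here, the single step between measured neighbours, a step that the two limits leave unreadable from compound 1 to compound 2, has both ends at that limit and its size cannot be read. Among the measured compounds shown here, compound 3 therefore stands exactly where every value so far stands, namely at the limit of > 26000 nM in this assay, at which 3 of the 3 values shown sit.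

Compound 4 `CCOC(=O)CCCCCOc1cccc(CN(C(=O)c2ccc(-c3cccc(F)c3)cc2)C(C)C)c1` is the next member; it differs from compound 3 by fluoro in place of benzyloxy on an aromatic carbon. No measured step covers this change, and the one step on record is unreadable, so nothing in the data separates any of these compounds from one another in this assay. The step from compound 3 to compound 4 is therefore expected to be a step that the limit leaves unreadable from compound 3 to compound 4, which is none beyond the scatter. Compound 4 is estimated at 50000 nM in this assay, with a range from 22000 nM to 150000 nM, and will most probably again be reported only as a limit.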

Compound 4, half-maximal effective concentration: > 26000 nM
Compound 4 gave a limit, no number; the forecaster's own chance of this, stated with the estimate: 85%; the middle value does not contradict the limit.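

In this assay compound 4 gives > 26000 nM, a limit and not a number. Its steps from compound 1, compound 2 and compound 3 therefore cannot be read. The compounds shown leave open at what concentration any of them reaches a half-maximal effect, and whether the groups on that aromatic carbon differ at all: the limit of > 26000 nM in this assay, at which 4 of the 4 values shown sit.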